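A Shorter Chain at the Assay Limit

This account rests on a few compounds, and the source may have more. Where it says the series, first, only, none or still open, it means among the compounds named here.

In a functional assay on KB cells (Homo sapiens) for cytotoxicity (a lower number here means a stronger inhibitor, a higher number a weaker inhibitor), compound 1 `COCCOCn1cc(C#N)c2c(N)ncnc21` reads > 100000 nM as a limit and not a number. Compound 2 `Cc1ccccc1Cn1cc(C#N)c2c(N)ncnc21` reads > 100000 nM as a limit too. Compound 3 `C=CCn1cc(C#N)c2c(N)ncnc21` reads > 100000 nM as a limit too. The evidence so far is the limit of > 100000 nM in this assay, at which 3 of the 3 values shown sit, and nothing firmer. Compound 4 `CCCn1cc(C#N)c2c(N)ncnc21` differs from compound 1 as ethyl in place of 2-methoxyethoxy on a saturated chain carbon bound to an aromatic nitrogen shows, with ethyl in place of 2-methoxyethoxy on a saturated chain carbon bound to an aromatic nitrogen. Within the data shown here, the one measured step that bears on this is a step that the two limits leave unreadable from compound 1 to compound 3 and it puts vinyl at that same place, so it offers no size to carry over. The expected step of a number no higher from compound 1 to compound 4 (the limit leaves the size open) is therefore none beyond the scatter, in no set direction. Compound 4 is estimated at 100000 nM with a range from 50000 nM to 200000 nM and will probably report only a limit again.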

Compound 4, half-maximal inhibitory concentration: > 100000 nM
Compound 4 ended at the assay's limit; the forecaster's own chance of this, stated with the estimate: 85%; the middle value sits exactly at the limit.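

Among these compounds, compound 4 gives only a limit, as do compound 1 and compound 3, so no step among them can be read. The compounds shown leave open what any of them would actually read in this assay, since the evidence stops at the limit: the limit of > 100000 nM in this assay, at which 4 of the 4 values shown sit.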